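A Plain Phenyl on the Way to Compound 3

The source may hold more compounds than are shown below. What is called first, only, known or untested is meant among the compounds shown, and "the series" means these compounds.

Compound 1 `O=C(/C=C/c1cccc(NC(=O)Nc2ccccc2)c1)C[C@@H]1OC[C@@H](O)[C@H](O)[C@H]1O`: 309000 nM
Compound 2 `COc1ccc(NC(=O)Nc2cccc(/C=C/C(=O)C[C@@H]3O[C@H](CO)[C@@H](O)[C@H](O)[C@H]3O)c2)c([N+](=O)[O-])c1`: 709000 nM

Among the measured compounds shown here, only two numbers are available so far, both from an ADME assay on Vero cells (Chlorocebus sabaeus) for cytotoxicity, read by resazurin assay, with a stated time of 2 days; a higher number here means that more compound is tolerated, a lower number that less compound is tolerated. Compound 2 stands highest at 709000 nM. Compound 1 is lower at 309000 nM, and this gap lies beyond the usual scatter of repeated measurements.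

The next molecule is compound 3 `O=C(/C=C/c1cccc(NC(=O)Nc2ccccc2)c1)C[C@@H]1O[C@H](CO)[C@@H](O)[C@H](O)[C@H]1O`. Going there from compound 2 places phenyl in place of 4-methoxy-2-nitrophenyl on an amide-type nitrogen. For the measured compounds named here, no measured pair shows this change on its own, so any forecast rests on thin evidence. Going by the values given here, the one guide is compound 1, which also bears a phenyl at that place and gives 309000 nM. It differs from compound 3 elsewhere, so it is only a rough reference.

On that basis, a modest downward move is expected in this assay, close to the edge of the scatter. The expected change is a 2.0-fold lower number from compound 2 to compound 3 (0.31 log units; beyond the scatter). The estimate for compound 3 is 350000 nM, with an expected range from 150000 nM to 800000 nM.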

Compound 3, half-maximal cytotoxic concentration: 373000 nM
Compound 3: the middle estimate sits 1.1-fold (0.03 log units) below what was measured; measured number inside the range.
By their numbers in this assay, from the lowest: compounds 1, 3 and 2 (each within the scatter of the next, the first and the last beyond it).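

In this assay, the exchange of 4-methoxy-2-nitrophenyl for phenyl on the amide-type nitrogen gives a 1.9-fold lower number from compound 2 to compound 3 (0.28 log units; within the scatter) and so cannot be told apart from no change, even though a larger group with a methoxy and a nitro substituent leaves and a bare aromatic ring enters. The second step concerns another place on the molecule: hydroxymethyl in place of hydrogen on a saturated ring carbon gives a 1.2-fold higher number from compound 1 to compound 3 (0.08 log units; within the scatter) and is likewise indistinguishable from no change, so in this pair of compounds that group makes no clear difference to how much compound the cells tolerate. No accompanying measurement offers an explanation for either step.

Each change is seen only once and on a single partner, so neither result can yet be taken as a general rule for these two places. Going by these compounds, it remains open whether a phenyl carrying a carboxylic acid or an amine on the nitrogen, or a longer chain such as hydroxyethyl or an aminomethyl group on the saturated ring carbon, would stay as close to compound 3 in this cell assay.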